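The compounds below may be only part of what the source reports. "The series", "measured", "known", "first", "only" and "open" are said of these compounds alone.

Compound 1, `COC(=O)/C=C\N(O)Cc1ccc(OCc2ccccc2)cc1`: 4800 nM
Compound 2, `CN(O)/C=C\C(=O)c1cc(C(F)(F)F)cc(C(F)(F)F)c1`: 910 nM
Compound 3, `O=C(/C=C\N(O)c1ccccc1)c1ccc(F)cc1`: 200 nM

All three were measured in an assay on RBL-1 cells for inhibition of Polyunsaturated fatty acid 5-lipoxygenase (Rattus norvegicus); on this read-out higher numbers stand for weaker inhibition and lower numbers for stronger inhibition. Compound 3 stands lowest of the three numbers with 200 nM. The nearest is compound 2, which gives 910 nM, and the furthest is compound 1 with 4800 nM; both gaps lie beyond the usual scatter, so compound 3 is the strongest inhibitor among the three.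

Compound 4, `O=C(/C=C\N(O)C1CCCCC1)c1ccc(F)cc1`, has not yet been measured. It differs from compound 3 in one place: cyclohexyl in place of phenyl on an amine nitrogen. Among the compounds with values here, no pair of measured compounds differs in this way alone, so the size of the step cannot be read from the data. Compound 2 carries a methyl on its amine nitrogen and gives a higher number than compound 3, but its structure differs in other places as well. The chemist therefore expects a modest weakening, a step of a 2.0-fold higher number from compound 3 to compound 4 (0.30 log units; within the scatter) in this assay. Compound 4 is estimated at 400 nM, within a range from 100 nM to 1600 nM.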

Compound 4, half-maximal inhibitory concentration: 270 nM
Beside the measured number, compound 4's estimate is 1.5-fold (0.17 log units) above it; the range from low to high includes it.
By their numbers in this assay, from the lowest: compounds 3 and 4 (each within the scatter of the next); then compound 2; then compound 1.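

In this assay, within the data shown here, the step of a 1.4-fold higher number from compound 3 to compound 4 (0.13 log units; within the scatter) gives the first direct reading at this position, and it lies within the scatter. On an amine nitrogen whose other neighbours are the double-bonded chain carbon and oxygen, the aromatic phenyl and the non-aromatic cyclohexyl give values that the assay cannot tell apart, so for this pair an aromatic ring at this place is not needed to keep the number in this range. No measurement shown here bears on why the two groups read alike.

The compounds shown leave open how a longer chain, such as n-butyl, or a cyclohexyl ring bearing a carboxylic acid or an amine would read on this nitrogen. Going by these compounds, compound 2 carries a methyl there but differs in other places as well, so the effect of a small group at this position remains unknown.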